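Adding a second chlorine to a quinoline urea

The source may hold more compounds than are shown below. What is called first, only, known or untested is meant among the compounds shown, and "the series" means these compounds.

Measured so far:
- compound 1, `Cc1cc(NC(=O)Nc2cccc(Cl)c2)c2ccccc2n1`: 19000 nM
- compound 2, `Cc1cc(NC(=O)Nc2cccc(C(N)=O)c2)c2ccccc2n1`: > 25000 nM

Two ureas built on a shared core have been tested in an ADME assay on HepG2 cells (Homo sapiens) for cytotoxicity, with a stated time of 72 h; on this read-out lower numbers stand for an effect already at smaller amounts and higher numbers for an effect only at larger amounts of compound. Among the measured compounds shown here, compound 1, `Cc1cc(NC(=O)Nc2cccc(Cl)c2)c2ccccc2n1`, gives 19000 nM, the only outright number among the two results. Compound 2, `Cc1cc(NC(=O)Nc2cccc(C(N)=O)c2)c2ccccc2n1`, reaches only the limit of the assay, > 25000 nM, so its value is a limit and not a number. The step between them, an at least 1.3-fold higher number from compound 1 to compound 2 (0.11 log units; that floor lies within the scatter), comes with carbamoyl in place of chloro on an aromatic carbon, and its floor sits within the scatter (the limit of > 25000 nM in this assay, at which 1 of the 2 values shown sits).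

Compound 3, `Cc1cc(NC(=O)Nc2ccc(Cl)c(Cl)c2)c2ccccc2n1`, is the compound still to be measured. It differs from compound 1 by chloro in place of hydrogen on an aromatic carbon. For the measured compounds named here, no measured step shows what a second chloro does; the only known step swaps chloro for a different group. For compound 3 the expected step is therefore a 1.6-fold lower number from compound 1 to compound 3 (0.20 log units; within the scatter), at most a small shift toward lower numbers and possibly none beyond the scatter. The estimate for compound 3 in this assay is 12000 nM, within 5000 nM to 25000 nM.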

Compound 3, half-maximal effective concentration: 17000 nM
Compound 3: middle estimate off by 1.4-fold (0.15 log units), on the low side; the measured number falls inside the stated range.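

In this assay, chloro in place of hydrogen, on the aromatic carbon ortho to a chloro group and para to a large group, gives a 1.1-fold lower number from compound 1 to compound 3 (0.05 log units; within the scatter), so this pair cannot be told apart on this read-out. Among the compounds shown here, this is the first direct look at this position, as the earlier step swapped the existing chloro for carbamoyl and left this aromatic carbon carrying hydrogen, and here a second chloro leaves the number within the usual scatter. Compound 2 remains the only one of the three compounds whose value is a limit and not a number: the limit of > 25000 nM in this assay, at which 1 of the 3 values shown sits.

The compounds shown test only hydrogen and chloro on this carbon, so it remains open whether a larger or different group, such as an amine, a carboxylic acid or a longer chain, would move the number beyond the scatter. It is also open whether chloro on this carbon would give the same small step without the first chloro in place, as no compound shown carries it alone.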